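Carbonyl substituent change on the shared core

This account rests on a few compounds, and the source may have more. Where it says the series, first, only, none or still open, it means among the compounds named here.

Measured in a functional assay on HEK293 cells for agonist activity at lutropin-choriogonadotropic hormone receptor (Homo sapiens), read by cAMP accumulation; a lower number here means a smaller maximal response, a higher number a larger maximal response:
compound 1 `CCOC(=O)c1sc2nc(SC)nc(-c3cccc(OC)c3)c2c1N` gives 4.2%
compound 2 `COc1cccc(-c2nc(SC)nc3sc(C(=O)OC(C)(C)C)c(N)c23)c1` gives 23.8%

Compound 1 sits at the lower of the two numbers in this assay; its nearest neighbour is compound 2, with the step of a number 19.6 percentage points higher from compound 1 to compound 2 (beyond the scatter), which replaces ethyl with tert-butyl on the oxygen of the ester.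

Compound 3 `COc1cccc(-c2nc(SC)nc3sc(C(=O)NNC(=O)OC(C)(C)C)c(N)c23)c1` is the next point. Relative to compound 1 the change is ((tert-butoxycarbonyl)amino)amino in place of ethoxy on a carbonyl carbon. The tert-butyl-bearing oxygen that appears in compound 2 is present here too, but now joined to the carbonyl through two nitrogens rather than directly. Among the compounds with values here, the only measured step that bears on this is a number 19.6 percentage points higher from compound 1 to compound 2 (beyond the scatter), a modest rise. Within the data shown here, a rise of comparable size, and possibly somewhat larger, is therefore expected for compound 3, with wide uncertainty since no measured step covers the two nitrogens. Compound 3 is estimated at 25%, range 5% to 50%, a step of a number 20.8 percentage points higher from compound 1 to compound 3 (beyond the scatter) expected from the change.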

Compound 3, largest response reached (reported as efficacy), in percent of the reference or control that the assay uses: 2.4%
Compound 3: the middle estimate sits 22.6 percentage points above what was measured; measured number outside the range, below it.
By their numbers in this assay, from the lowest: compounds 3 and 1 (each within the scatter of the next); then compound 2.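

At the carbonyl carbon, the higher response seen with tert-butoxy does not carry over to ((tert-butoxycarbonyl)amino)amino: in this assay the change gives a number 21.4 percentage points lower from compound 2 to compound 3 (beyond the scatter), and against the ethoxy compound it gives a number 1.8 percentage points lower from compound 1 to compound 3 (within the scatter). A tert-butyl group at the end of the substituent therefore does not by itself go with the larger maximal response, since compound 3 carries one and stays level with compound 1. No available data explain the gap between the tert-butoxy and ((tert-butoxycarbonyl)amino)amino groups.

Open, from the compounds shown here alone, is whether the two nitrogens or the added carbonyl matter more, which a plain hydrazide on this carbonyl carbon would help to separate. Also open, going by these compounds, is how a primary amide or the free carboxylic acid would read here.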